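Chloro to bromo on the benzyl group of compound 3

The source may hold more compounds than are shown below. What is called first, only, known or untested is meant among the compounds shown, and "the series" means these compounds.

Compound 1 `Brc1ccc(Cn2c(CC3CCCC3)nc3ccccc32)cc1` gives 8400 nM in an assay on microsomes from brain for inhibition of heme oxygenase 2 (Rattus norvegicus), using NADPH, with stated times of 10 min and 15 min; on this read-out higher numbers stand for weaker inhibition and lower numbers for stronger inhibition.
Compound 2 `Brc1ccc(Cn2c(CC3CC4CCC3C4)nc3ccccc32)cc1` gives 5100 nM in this assay.
Compound 3 `Clc1ccc(Cn2c(CC3CCCCC3)nc3ccccc32)cc1` gives 5400 nM in this assay.

Compound 3 sits within the usual scatter of both compound 2 and compound 1, so the three numbers cannot be told apart. Compound 4 `Brc1ccc(Cn2c(CC3CCCCC3)nc3ccccc32)cc1` carries bromo in place of chloro on an aromatic carbon. Going by the values given here, no measured pair tests this exchange on its own: the only single-point step, a 1.6-fold lower number from compound 1 to compound 2 (0.22 log units; within the scatter), concerns the saturated ring and stays within the scatter, and compound 1 and compound 3 differ in two places at once. With nothing pointing either way, the expected step from compound 3 to compound 4 in this assay is a 1.1-fold lower number from compound 3 to compound 4 (0.03 log units; within the scatter), no larger than the scatter. Compound 4 is therefore estimated at 5000 nM, within 2500 nM to 10000 nM.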

Compound 4, half-maximal inhibitory concentration: 5400 nM
The estimate for compound 4 lay 1.1-fold (0.03 log units) below the measured number; low and high end bracket the measured number.
By their numbers in this assay, from the lowest: compounds 2, 3, 4 and 1 (each within the scatter of the next).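

In this assay the first direct test of bromo in place of chloro on the benzyl group gives no change at the digits printed from compound 3 to compound 4 (within the scatter) and so shows no effect of this exchange on the number. With bromo held fixed, cyclohexyl in place of cyclopentyl gives a 1.6-fold lower number from compound 1 to compound 4 (0.19 log units; within the scatter) and the cyclohexyl group against the two-ring group of compound 2 gives a 1.1-fold higher number from compound 2 to compound 4 (0.02 log units; within the scatter) so neither ring exchange is told apart from the scatter. No supporting measurement explains why these numbers stay so close.

Still open, as far as these compounds go, is whether an amine or a carboxylic acid in place of the bromo would shift the number. So is whether a longer chain in place of the saturated ring would do so.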